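The source may report more compounds than this note shows. Statements on the series, on what has been measured and on what is new or still open speak of the compounds shown alone.

The measured compounds:
compound 1, `OC[C@H]1O[C@@H](n2cnc3c(NCc4ccc(F)cc4)ncnc32)[C@H](O)[C@@H]1O`, gives 2700 nM in a functional assay on K562 cells (Homo sapiens) for antiproliferative activity, with a stated time of 72 h; a higher number here means a weaker inhibitor, a lower number a stronger inhibitor;
compound 2, `OC[C@H]1O[C@@H](n2cnc3c(NCc4ccc(F)cc4F)ncnc32)[C@H](O)[C@@H]1O`, gives 9600 nM in this assay.

Compound 1 holds the lower of the two numbers, so it is the stronger of the measured pair. For the measured compounds named here, the only measured step, a 3.6-fold higher number from compound 1 to compound 2 (0.55 log units; beyond the scatter), came with a fluoro in place of hydrogen on an aromatic carbon, and it weakened the compound modestly.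

Compound 3, `COc1cccc(CNc2ncnc3c2ncn3[C@@H]2O[C@H](CO)[C@@H](O)[C@H]2O)c1O`, is the next compound in line. Its change from compound 1 is 2-hydroxy-3-methoxyphenyl in place of 4-fluorophenyl on a saturated chain carbon bound to a nitrogen on an aromatic ring. Going by the values given here, no measured step swaps the whole ring in this way, so the single known step is only a loose guide: altering the ring once weakened activity beyond the scatter, and a larger alteration is expected to weaken it too, with wide uncertainty. For compound 3 the expected step is a 1.9-fold higher number from compound 1 to compound 3 (0.27 log units; within the scatter). Compound 3 is therefore estimated at 5000 nM, within a range from 1500 nM to 20000 nM.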

Compound 3, half-maximal inhibitory concentration: 27900 nM
Compound 3: middle estimate off by 5.6-fold (0.75 log units), on the low side; measured number above the stated range.
By their numbers in this assay, from the lowest: compound 1; then compound 2; then compound 3.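

On the saturated chain carbon bound to a nitrogen on an aromatic ring, replacing the whole ring costs more in this assay than the earlier fluoro change did. Putting 2-hydroxy-3-methoxyphenyl in place of 4-fluorophenyl gives a large step (a 10-fold higher number from compound 1 to compound 3 (1.01 log units; beyond the scatter)), and putting it in place of 2,4-difluorophenyl still gives a modest one beyond the scatter (a 2.9-fold higher number from compound 2 to compound 3 (0.46 log units; beyond the scatter)). Both fluorinated rings therefore stand ahead of the ring bearing hydroxy and methoxy groups, though no measurement here explains this difference.

Going by these compounds, the hydroxy and methoxy groups enter together, so their separate contributions stay unknown. On these data alone, whether 2-hydroxyphenyl, 3-methoxyphenyl or plain phenyl would match 4-fluorophenyl or fall toward 2-hydroxy-3-methoxyphenyl remains open, as does the outcome for a ring carrying an amine.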